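Adding a trifluoromethyl group to compound 3

The compounds below may be only part of what the source reports. "The series", "measured", "known", "first", "only" and "open" are said of these compounds alone.

Compound 1 `Cn1nc(C(F)(F)F)c2c(-c3ccccc3)cc(NNC(=O)Nc3cc(Cl)nc(Cl)c3)nc21` gives 13100 nM
Compound 2 `CC(C)c1cc(NNC(=O)Nc2cc(Cl)nc(Cl)c2)nc2c1c(C(F)(F)F)nn2C` gives 19100 nM
Compound 3 `CCCc1cc(NNC(=O)Nc2cc(Cl)nc(Cl)c2)nc2c1cnn2C` gives 38700 nM

In a functional assay on SW620/5-FU cells (Homo sapiens) for cytotoxicity, read by MTT assay, with a stated time of 48 h, in the presence of a further agent that is not named here (on this read-out lower numbers stand for an effect already at smaller amounts and higher numbers for an effect only at larger amounts of compound), compound 3 gives 38700 nM, the highest of the three numbers and beyond the scatter from both of the others. Compound 4 `CCCc1cc(NNC(=O)Nc2cc(Cl)nc(Cl)c2)nc2c1c(C(F)(F)F)nn2C` differs from compound 3 by a single change, trifluoromethyl in place of hydrogen on an aromatic carbon.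

Within the data shown here, no measured step isolates this change. Among the measured compounds shown here, the only step available is a 1.5-fold higher number from compound 1 to compound 2 (0.16 log units; within the scatter), and it concerns a different substituent, on an aromatic carbon, with trifluoromethyl present on both sides. It suggests that, among these two compounds, swapping that substituent moves the number little. Compound 1 and compound 2 both carry trifluoromethyl, and both have lower numbers than compound 3, which lacks it. This rests on very few compounds, and compound 3 also differs from them in its other substituent.

A moderate step towards a lower number in this assay is therefore expected, close to the edge of the scatter. The estimated change is a 1.9-fold lower number from compound 3 to compound 4 (0.29 log units; within the scatter). For compound 4 the expected value is 20000 nM, with an estimated range from 10000 nM to 38000 nM.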

Compound 4, half-maximal effective concentration: 11700 nM
The estimate for compound 4 lay 1.7-fold (0.23 log units) above the measured number; the range from low to high includes it.
By their numbers in this assay, from the lowest: compounds 4, 1 and 2 (each within the scatter of the next); then compound 3.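

Here the position is read directly for the first time: in this assay, with propyl held constant, trifluoromethyl in place of hydrogen on an aromatic carbon of the five-membered aromatic ring gives a step beyond the scatter (a 3.3-fold lower number from compound 3 to compound 4 (0.52 log units; beyond the scatter)), where the earlier compounds offered only a comparison in which the other substituent differed as well. With trifluoromethyl in place, that other substituent still moves the number little, as both remaining steps lie within the scatter (a 1.6-fold lower number from compound 2 to compound 4 (0.21 log units; within the scatter)) and (a 1.1-fold lower number from compound 1 to compound 4 (0.05 log units; within the scatter)), so propyl, isopropyl and phenyl cannot be told apart among these compounds in this read-out. Nothing measured here speaks to the reason for the trifluoromethyl step.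

The compounds shown leave open whether trifluoromethyl gives a step of similar size when phenyl or isopropyl takes the place of propyl, as only the propyl pair has both the hydrogen and the trifluoromethyl form. They also leave open how a nitrile or an amine in place of trifluoromethyl, or a longer chain in place of propyl, would compare in this assay.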